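The compounds below may be only part of what the source reports. "The series", "measured", "known", "first", "only" and "open" are said of these compounds alone.

Working notes on the series. Compound 1 `CC(=O)N1N=C(c2ccc(C)cc2)CC1c1ccc(C(=O)OC(C)Cn2c([N+](=O)[O-])cnc2C)cc1` in a functional assay on MCF7 cells (Homo sapiens) for antiproliferative activity, read by MTT assay, with a stated time of 12 h (a higher number here means a weaker inhibitor, a lower number a stronger inhibitor), gives 92100 nM. For the measured compounds named here, compound 2 `COc1ccc(C2=NN(C(C)=O)C(c3ccc(C(=O)OC(C)Cn4c([N+](=O)[O-])cnc4C)cc3)C2)cc1` in this assay gives 28000 nM, the lowest of the two numbers so far; the only measured step, a 3.3-fold lower number from compound 1 to compound 2 (0.52 log units; beyond the scatter), is a methoxy in place of methyl on an aromatic carbon. Compound 3 `CC(=O)N1N=C(c2ccc([N+](=O)[O-])cc2)CC1c1ccc(C(=O)OC(C)Cn2c([N+](=O)[O-])cnc2C)cc1` differs from compound 2 by nitro in place of methoxy on an aromatic carbon. Going by the values given here, no measured step changes this methoxy, so the single step from compound 1 to compound 2 gives only a sense of scale, not direction; a modest step in this assay is expected for compound 3, estimated as a 1.4-fold lower number from compound 2 to compound 3 (0.15 log units; within the scatter). Compound 3 is expected near 20000 nM, within 6000 nM to 70000 nM.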

Compound 3, half-maximal inhibitory concentration: 3330 nM
The estimate for compound 3 lay 6.0-fold (0.78 log units) above the measured number; the whole stated range lies above it.
By their numbers in this assay, from the lowest: compound 3; then compound 2; then compound 1.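

At this position, on an aromatic carbon para to a large group, nitro sets a new low in this assay with an 8.4-fold lower number from compound 2 to compound 3 (0.92 log units; beyond the scatter) and so separates clearly from methoxy. Nitro in place of methyl gives a 28-fold lower number from compound 1 to compound 3 (1.44 log units; beyond the scatter) and is the only large step so far, so the position tolerates substantial shifts in this assay's number with a single group change. Nothing available accounts for the order methyl, methoxy, nitro. From the compounds shown here alone, whether an amine, a carboxylic acid or a chlorine atom here would extend that order remains open, as does whether it holds when the shared core changes.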